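Fluoro in place of bromo in compound 3

The source may hold more compounds than are shown below. What is called first, only, known or untested is meant among the compounds shown, and "the series" means these compounds.

Going by the values given here, in a functional assay on HeLa cells (Homo sapiens) for inhibition, read by CCK-8 assay, with a stated time of 72 h, tested at 8 uM (a higher number here means more inhibition of growth at the concentration tested, a lower number less inhibition of growth), compound 3 (`Nc1ccccc1NC(=O)c1ccc(CSc2ccc(Br)cc2)cc1`) gives 38.2%, the lowest of the three numbers so far. Compound 1 (`CCc1ccc(SCc2ccc(C(=O)Nc3ccccc3N)cc2)cc1`) gives 71% and compound 2 (`Cc1ccc(SCc2ccc(C(=O)Nc3ccccc3N)cc2)cc1`) gives 79.2%. Compound 4 (`Nc1ccccc1NC(=O)c1ccc(CSc2ccc(F)cc2)cc1`) carries fluoro in place of bromo on an aromatic carbon, para to a large group: fluoro in place of bromo on an aromatic carbon. Two measured steps change the group at this same place, a number 32.8 percentage points lower from compound 1 to compound 3 (beyond the scatter) and a number 41 percentage points lower from compound 2 to compound 3 (beyond the scatter), and both are large. Among the compounds with values here, no fluoro compound has been measured, so these steps give only a rough guide, and a partial rise is expected. The estimated change is a number 16.8 percentage points higher from compound 3 to compound 4 (beyond the scatter). For compound 4 the expected value is 55%, with an estimated range from 35% to 78%.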

Compound 4, percent growth inhibition at one concentration: 79.3%
Estimate against measurement, compound 4: 24.3 percentage points below; measured number above the stated range.
By their numbers in this assay, from the lowest: compound 3; then compounds 1, 2 and 4 (each within the scatter of the next).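

In this assay the change from 4-bromophenyl to 4-fluorophenyl gives a number 41.1 percentage points higher from compound 3 to compound 4 (beyond the scatter) and shows that a halogen at this position does not by itself bring the low number. Fluoro instead stands level with the alkyl groups, with a number 0.1 percentage points higher from compound 2 to compound 4 (within the scatter) and a number 8.3 percentage points higher from compound 1 to compound 4 (within the scatter), leaving compound 3 as the only one of the four apart from the rest. Nothing at hand explains this separation of bromo from fluoro. On these data alone, it remains open whether chloro would fall with bromo or stay with fluoro, and how an amine or a carboxylic acid at this place would read.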